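Swapping the Azole on Compound 1

The source may hold more compounds than are shown below. What is called first, only, known or untested is meant among the compounds shown, and "the series" means these compounds.

Compound 1 `COc1ccc2c(=O)c(-c3ccccc3)c(-n3ccnc3)oc2c1` serves as the reference point. Within the data shown here, in an assay for inhibition of Aromatase (Homo sapiens) (a lower number here means a stronger inhibitor, a higher number a weaker inhibitor), compound 1 gives 770 nM, the second highest of the three numbers measured so far. Its nearest neighbour is compound 3 `O=c1c(-c2ccccc2)c(-n2ccnc2)oc2cc(OCc3ccccc3)ccc12`, which gives 520 nM; the step of a 1.5-fold lower number from compound 1 to compound 3 (0.17 log units; within the scatter) lies within the scatter. Compound 2 `COc1ccc(-c2c(-n3ccnc3)oc3cc(OC)ccc3c2=O)cc1`, with 2000 nM, stands furthest away, and the step of a 2.6-fold higher number from compound 1 to compound 2 (0.41 log units; beyond the scatter) goes beyond the scatter.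

Compound 4 `COc1ccc2c(=O)c(-c3ccccc3)c(-n3cncn3)oc2c1` has not been measured. It differs from compound 1 by 1H-1,2,4-triazol-1-yl in place of 1H-imidazol-1-yl on an aromatic carbon. Neither measured step bears directly on this change: the step from compound 1 to compound 3 puts phenyl in place of hydrogen on a saturated chain carbon bound to an oxygen on an aromatic ring, and the step from compound 1 to compound 2 puts methoxy in place of hydrogen on an aromatic carbon; both leave the 1H-imidazol-1-yl untouched. With no comparable exchange among the measured compounds, compound 4 is expected to stay close to compound 1, with a step of a 1.3-fold higher number from compound 1 to compound 4 (0.11 log units; within the scatter) that need not exceed the scatter. Compound 4 is therefore estimated at 1000 nM, within 300 nM to 3500 nM.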

Compound 4, half-maximal inhibitory concentration: 18000 nM
Estimate against measurement, compound 4: 18-fold (1.26 log units) below; the measured number lies above the stated range.
By their numbers in this assay, from the lowest: compounds 3 and 1 (each within the scatter of the next); then compound 2; then compound 4.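

In this assay, the azole position on the aromatic carbon next to the ring oxygen proves far more sensitive than the places changed earlier: 1H-1,2,4-triazol-1-yl in place of 1H-imidazol-1-yl gives a 23-fold higher number from compound 1 to compound 4 (1.37 log units; beyond the scatter), a much larger step than a 2.6-fold higher number from compound 1 to compound 2 (0.41 log units; beyond the scatter) or a 1.5-fold lower number from compound 1 to compound 3 (0.17 log units; within the scatter). The size of this step does not follow from bulk as counted, since both groups are five-membered aromatic rings with 5 heavy atoms and no net charge, and the entering ring differs by holding 3 hetero atoms where the leaving ring holds 2. Nothing available accounts for the step.

On these data alone, it remains open how 1H-pyrazol-1-yl or a dimethylamino group would fare on this carbon. As far as these compounds go, whether the same exchange would give a step of this size on compound 3 also remains open.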